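This account rests on a few compounds, and the source may have more. Where it says the series, first, only, none or still open, it means among the compounds named here.

Compound 2 `CCOC(=O)c1sc(-c2cccc(NC(=O)c3ccccc3F)c2)nc1Nc1ccc(N2CCN(C)CC2)cc1` stands highest of the three compounds measured in a functional assay on Ramos cells (Homo sapiens) for antiproliferative activity, read by CCK-8 assay, with a stated time of 72 h, tested at 40 uM (a lower number here means less inhibition, a higher number more inhibition at the concentration tested (going by the name of the read-out)), where compound 2 gives 96.4%. Its nearest neighbour is compound 1 `CCOC(=O)c1sc(-c2cccc(NC(=O)c3ccccc3)c2)nc1Nc1ccc(N2CCN(C)CC2)cc1`, for which compound 1 gives 77.1%, a step of a number 19.3 percentage points higher from compound 1 to compound 2 (beyond the scatter). Furthest lies compound 3 `CCOC(=O)c1sc(-c2cccc(NC(=O)[C@H]3CC[C@H](C)CC3)c2)nc1Nc1ccc(N2CCN(C)CC2)cc1`, as compound 3 gives 19.9%, the step being a number 76.5 percentage points lower from compound 2 to compound 3 (beyond the scatter); compound 1 to compound 3 shows a number 57.2 percentage points lower from compound 1 to compound 3 (beyond the scatter).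

Compound 4 `CN1CCN(c2ccc(Nc3nc(-c4cccc(NC(=O)c5ccccc5F)c4)sc3C(N)=O)cc2)CC1` differs from compound 2 only at the carbonyl carbon bearing the ethoxy group: amino in place of ethoxy on a carbonyl carbon. Going by the values given here, none of the measured steps touches this position; all three alter the group on the carbonyl carbon of the amide at the far side of the shared core, and they range from modest to large. The data therefore give no direct guide to the ethoxycarbonyl-to-carbamoyl exchange. With the rest of compound 2 retained, a step of a number 18.4 percentage points lower from compound 2 to compound 4 (beyond the scatter) is expected, most likely within or near the scatter. Compound 4 is thus estimated at 78%, in the range 40% to 99%.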

Compound 4, a percentage reported as inhibition, at one concentration (the size of the read-out at that concentration, not a potency): 95.5%
Beside the measured number, compound 4's estimate is 17.5 percentage points below it; low and high end bracket the measured number.
By their numbers in this assay, from the lowest: compound 3; then compound 1; then compounds 4 and 2 (each within the scatter of the next).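

In this assay, going by these compounds alone, amino in place of ethoxy on a carbonyl carbon gives a number 0.9 percentage points lower from compound 2 to compound 4 (within the scatter), the first reading at this position, as every earlier step changed the group on the amide carbonyl at the far side of the shared core. With the 2-fluorophenyl amide retained, ethoxycarbonyl and carbamoyl therefore read alike at this single concentration, which shows that the ethoxy group is not required for the inhibition seen with compound 2, though a single-concentration reading says nothing about potency. No measurement shown here accounts for this result.

As far as these compounds go, what a carboxylic acid or a longer ester chain such as propoxycarbonyl would give on this carbonyl carbon remains open. From the compounds shown here alone, it is equally open whether carbamoyl would read the same in the setting of compound 3, which gives 19.9%.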